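From compound 3 to compound 4: a longer chain

The source may hold more compounds than are shown below. What is called first, only, known or untested is meant among the compounds shown, and "the series" means these compounds.

Values so far in a functional assay on L1210 cells (Mus musculus) for inhibition, with a stated time of 48 h (on this read-out higher numbers stand for weaker inhibition and lower numbers for stronger inhibition), each one a limit:
- compound 1 `CNCCCNCCCNC` gives > 100000 nM as its limit
- compound 2 `CCCNCCCNCCCNCCC` gives > 100000 nM as its limit
- compound 3 `CNCCCCNCCCNC` gives > 100000 nM as its limit

Compound 3 has no number, and it stands with the others at the limit of > 100000 nM in this assay, at which 3 of the 3 values shown sit, in this read-out. Compound 4 `CNCCCCCNCCCCNC` carries 2-(methylamino)ethyl in place of methylamino on a saturated chain carbon, three bonds along the chain from an amine nitrogen and is still unmeasured. Among the compounds with values here, the only related change is a step that the two limits leave unreadable from compound 1 to compound 3 and it offers no size to carry over. No step beyond the scatter is therefore expected in this assay for compound 4. The expected step is a number no higher from compound 3 to compound 4 (the limit leaves the size open) in size. Compound 4 is estimated at 100000 nM within an expected range of 30000 nM to 200000 nM and will probably be reported only as a limit.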

Compound 4, half-maximal inhibitory concentration: 2000 nM
The estimate for compound 4 lay 50-fold (1.70 log units) above the measured number; the whole stated range lies above it.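

In this assay, within the data shown here, putting 2-(methylamino)ethyl in place of methylamino on a saturated chain carbon, three bonds along the chain from an amine nitrogen, gives an at least 50-fold lower number from compound 3 to compound 4 (1.69 log units; beyond the scatter) and so the first readable step at this place. The earlier step to (methylamino)methyl cannot be read, so this place had shown no measurable response to the change until now. Compound 4 alone has moved off the limit shared by the other compounds: the limit of > 100000 nM in this assay, at which 3 of the 4 values shown sit.

The compounds shown leave open whether a longer chain, such as 3-(methylamino)propyl, would lower the number further. They also leave open whether the terminal amine is needed, or whether a hydroxyl in its place would serve as well.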